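Alkoxybenzamide aminopyridines: step from butylamino to arylamino

The compounds below may be only part of what the source reports. "The series", "measured", "known", "first", "only" and "open" are said of these compounds alone.

Measured so far:
compound 1 `CCOc1ccc(C(=O)Nc2cc(C)cc(C)n2)cc1`, an in vitro assay on HEK-tsA201 cells for antagonist activity at Neuronal acetylcholine receptor; alpha3/beta4 (Homo sapiens), read by fluorescence and calcium flux; on this read-out lower numbers stand for stronger inhibition and higher numbers for weaker inhibition: 17400 nM
compound 2 `CCCCNc1cccc(NC(=O)c2ccc(OCCC)cc2)n1`, this assay: 77800 nM

Compound 2 stands at the higher of the two numbers; compound 1 sits lower by a gap that is beyond the usual scatter of repeated measurements. The two compounds differ in more than one place, so no single step is drawn between them; only their two values are shown.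

Compound 3 `CCCOc1ccc(C(=O)Nc2cccc(Nc3ccc(Cl)cc3)n2)cc1` is the next member, not yet measured. It differs from compound 2 in one place: 4-chlorophenyl in place of butyl on a nitrogen on an aromatic ring.

No measured pair in the series shows what this particular change does, so the direction rests on no shown step. The expectation for the step from compound 2 to compound 3 is a modest move toward a lower number, a 1.9-fold lower number from compound 2 to compound 3 (0.29 log units; within the scatter), with a wide range around it. Compound 3 is therefore estimated at 40000 nM, expected between 8000 nM and 150000 nM.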

Compound 3, half-maximal inhibitory concentration: > 100000 nM
Compound 3 gave a limit, no number; the forecaster's own chance of this, stated with the estimate: 15%; middle value at least 2.5-fold (0.39 log units) away from the limit.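

In this assay compound 3 gives > 100000 nM, which is a limit of the assay and not a number. The step reads as an at least 1.2-fold higher number from compound 2 to compound 3 (0.10 log units; that floor lies within the scatter), so 4-chlorophenyl in place of butyl on this nitrogen gives no sign of the lower number that a move to an aromatic ring might have brought. How far the true value of compound 3 lies past that floor stays unread because the result is a limit: the limit of > 100000 nM in this assay, at which 1 of the 3 values shown sits.

From the compounds shown here alone, whether a shorter chain such as ethyl, a saturated ring such as cyclohexyl or an unsubstituted phenyl on this nitrogen would give a number inside the range of the assay remains open. Also open, going by these compounds, is whether a chlorine elsewhere on the aromatic ring, or a methoxy group in its place, would read differently.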